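The compounds below may be only part of what the source reports. "The series", "measured", "known", "first", "only" and "open" are said of these compounds alone.

Of the compounds shown here, three have so far been measured in an assay for binding affinity to 5-hydroxytryptamine receptor 1F (Homo sapiens), read by radioligand binding; on this read-out higher numbers stand for weaker inhibition and lower numbers for stronger inhibition. Compound 2 `Cc1cccc(C(=O)Nc2ccc3[nH]cc(C4CCN(C)CC4)c3n2)c1` gives 5.8 nM, the lowest of the three numbers. Compound 3 `CCN1CC=C(c2c[nH]c3ccc(NC(=O)c4ccc(F)cc4)nc23)CC1` gives 25 nM, a gap beyond the scatter, and compound 1 `CC(=O)Nc1cc2c(C3CCN(C)CC3)c[nH]c2cn1` gives 210 nM, the furthest away. Compound 4 `CN1CCC(c2c[nH]c3ccc(NC(=O)Nc4ccc(F)cc4)nc23)CC1` has not yet been measured; set against compound 2 it shows ((4-fluorophenyl)amino in place of 3-methylphenyl on a carbonyl carbon). Among the compounds with values here, no measured pair isolates this change, so the expectation rests on the three values alone. The nearest neighbour of compound 2 in this assay is compound 3, which sits at 25 nM. A step towards weaker inhibition, beyond the scatter, is expected for compound 4, namely a 4.3-fold higher number from compound 2 to compound 4 (0.63 log units; beyond the scatter). Compound 4 is therefore estimated at 25 nM, within a range from 6 nM to 100 nM.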

Compound 4, inhibition constant: 11 nM
Estimate against measurement, compound 4: 2.3-fold (0.36 log units) above, and the stated range covers the measured number.
By their numbers in this assay, from the lowest: compounds 2 and 4 (each within the scatter of the next); then compound 3; then compound 1.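

In this assay, within the data shown here, (4-fluorophenyl)amino in place of 3-methylphenyl on a carbonyl carbon gives a 1.9-fold higher number from compound 2 to compound 4 (0.28 log units; within the scatter) and is the first step at this position. The entering group brings a nitrogen, a hydrogen-bond donor and a fluorine, yet compound 2 and compound 4 cannot be told apart on this read-out. Nothing at hand offers a reason for this result. Which of these entering features counts, if any, stays open, as they enter together. The compounds shown also do not settle how phenylamino without the fluorine, or the smaller methylamino, would read on this carbonyl carbon.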